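The compounds below may be only part of what the source reports. "The series", "measured", "known", "first", "only" and "open" are said of these compounds alone.

In a functional assay on PANC-1 cells (Homo sapiens) for antiproliferative activity, read by sulforhodamine B assay, with a stated time of 48 h (a higher number here means a weaker inhibitor of growth, a lower number a stronger inhibitor of growth), compound 1 (`Cc1cc2c(cc1C)C(Cl)=C(c1nnc(Nc3ccccc3)s1)CCC2`) gives 3670 nM, while compound 2 (`ClC1=C(c2nnc(-c3ccccc3)o2)CCCc2ccccc21`) gives 675 nM. Compound 2 therefore holds the lower of the two numbers, and the gap between them lies beyond the usual scatter of repeated measurements. Compound 3 (`Cc1ccc(-c2nnc(C3=C(Cl)c4ccccc4CCC3)o2)cc1`) has yet to be measured. It departs from compound 2 at a single place, with methyl in place of hydrogen on an aromatic carbon, turning phenyl into 4-methylphenyl: methyl in place of hydrogen on an aromatic carbon. For the measured compounds named here, no measured pair here shows what this change does, so the only anchor is compound 2 at 675 nM, and no direction can be argued from the data. The expected change, a 1.1-fold lower number from compound 2 to compound 3 (0.04 log units; within the scatter), is none beyond the scatter. Compound 3 is estimated at 620 nM, with an expected range from 220 nM to 1800 nM.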

Compound 3, concentration for 50% growth inhibition: 6810 nM
The estimate for compound 3 lay 11-fold (1.04 log units) below the measured number, outside the stated range (above it).
By their numbers in this assay, from the lowest: compound 2; then compounds 1 and 3 (each within the scatter of the next).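

For the compounds shown here, this is the first direct reading of this change in this assay. Methyl in place of hydrogen, on an aromatic carbon para to a large group, gives a 10-fold higher number from compound 2 to compound 3 (1.00 log units; beyond the scatter) and so weakens growth inhibition. This position is therefore not indifferent to substitution in this series, as the single added carbon that turns phenyl into 4-methylphenyl moves the number beyond the scatter, and no measurement offered here accounts for the size of that shift.

Going by these compounds, what remains open is whether this loss is particular to methyl or extends to other groups at this position, such as fluorine, methoxy or an amine. On these data alone, it is also open whether a longer chain such as ethyl would move the number further in the same direction.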